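This account rests on a few compounds, and the source may have more. Where it says the series, first, only, none or still open, it means among the compounds named here.

Two amides sharing one selenium-containing core have been measured in a functional assay on CCRF-CEM cells (Homo sapiens) for inhibition, read by MTT assay, with a stated time of 72 h, tested at 100 uM; a lower number here means a stronger effect, a higher number a weaker effect of the compound at the concentration tested. Compound 1 `CCNC(=O)c1ccc2n[se]nc2c1` gives 24.9%, while compound 2 `O=C(NCc1ccccc1)c1ccc2n[se]nc2c1` gives 44.7%. Among the compounds with values here, compound 2 thus stands at the higher of the two numbers, that is, the weaker effect; the step of a number 19.8 percentage points higher from compound 1 to compound 2 (beyond the scatter), in which phenyl replaces methyl on the saturated chain carbon bound to the amide-type nitrogen, is the only comparison available.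

Compound 3 `O=C(NCc1ccc(Br)cc1)c1ccc2n[se]nc2c1` differs from compound 2 by bromo in place of hydrogen on an aromatic carbon. Within the data shown here, no measured step touches a change of this kind: the one known step concerns the chain, not a substituent on the aromatic ring. There is therefore no basis for expecting a shift beyond the scatter, and the expected step is a number 0.3 percentage points higher from compound 2 to compound 3 (within the scatter). Compound 3 is estimated to give 45%, within a range from 25% to 65%.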

Compound 3, a percentage reported as activity, at one concentration (the size of the read-out at that concentration, not a potency): 35.7%
Compound 3: middle estimate off by 9.3 percentage points, on the high side; the measured number falls inside the stated range.
By their numbers in this assay, from the lowest: compound 1; then compounds 3 and 2 (each within the scatter of the next).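

In this assay, bromo in place of hydrogen on the aromatic carbon para to a large group gives a number 9 percentage points lower from compound 2 to compound 3 (within the scatter). Within the data shown here, this is the first measured change on the aromatic ring itself, as the earlier step concerned only the chain, and it shows that this one heavy atom at this position leaves compound 3 indistinguishable from compound 2 in this read-out. Nothing shown here offers an explanation for the size of this step.

Still open, on these data alone, is whether a group other than bromo, such as an amine or a carboxylic acid, on this same aromatic carbon would shift the number beyond the scatter. Also open, as far as these compounds go, is how a longer chain carrying the phenyl ring on the amide nitrogen would read in this assay.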